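Replacing furan-3-yl with 2,5-dimethylthiophen-3-yl

The source may hold more compounds than are shown below. What is called first, only, known or untested is meant among the compounds shown, and "the series" means these compounds.

In an ADME assay on MDCK cells (Canis lupus familiaris) for cytotoxicity, read by MTT assay, with a stated time of 24 h (on this read-out higher numbers stand for lower toxicity in this test and lower numbers for higher toxicity in this test), compound 1 (`Cc1cc(CNS(=O)(=O)c2ccc([N+](=O)[O-])cc2)c(C)o1`) reads > 152000 nM, which is a limit of the assay. Going by the values given here, compound 2 (`Cc1cc(CNS(=O)(=O)c2ccc(C#N)cc2)c(C)o1`) gives 105000 nM, the only value so far that is not a limit. Compound 3 (`O=[N+]([O-])c1ccc(S(=O)(=O)NCc2ccoc2)cc1`) stands at > 236000 nM, which is also a limit of the assay.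

Compound 4 (`Cc1cc(CNS(=O)(=O)c2ccc([N+](=O)[O-])cc2)c(C)s1`) follows from compound 3 through (2,5-dimethylthiophen-3-yl in place of furan-3-yl on a saturated chain carbon bound to a sulfonamide nitrogen). Among the compounds with values here, two measured steps bear on this change. The exchange at the same place, a step that the two limits leave unreadable from compound 1 to compound 3, has no readable size. The exchange of nitro for cyano, an at least 1.4-fold lower number from compound 1 to compound 2 (0.16 log units; that floor lies within the scatter), sits at another place and has a floor within the scatter. Within the data shown here, no measured compound carries 2,5-dimethylthiophen-3-yl, so the expectation rests mainly on compound 2 at 105000 nM as the one measured number. Only a small move in this assay is therefore expected. The estimated change is an at least 1.8-fold lower number from compound 3 to compound 4 (0.25 log units; that floor lies within the scatter), towards a lower number. The estimated value for compound 4 is 130000 nM, with an expected range of 60000 nM to 300000 nM.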

Compound 4, half-maximal cytotoxic concentration: > 204000 nM
Compound 4: only a limit was reported; the forecaster's own chance of this, stated with the estimate: 55%; middle value at least 1.5-fold (0.19 log units) away from the limit.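

Compound 1, compound 3 and compound 4 are all reported as limits, so neither the step from compound 3 to compound 4 nor the step from compound 1 to compound 4 can be read. The compounds shown leave open how 2,5-dimethylthiophen-3-yl compares with furan-3-yl or 2,5-dimethylfuran-3-yl in this assay.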